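Unmasking the hydroxamic acid in a quinolinone sulfonamide

The source may report more compounds than this note shows. Statements on the series, on what has been measured and on what is new or still open speak of the compounds shown alone.

The study compares two quinolinone sulfonamides in a functional assay on HL-60 cells (Homo sapiens) for antiproliferative activity, tested at 100 uM; a higher number here means a stronger effect of the compound at the concentration tested, a lower number a weaker effect. Compound 1 `Cc1cc2cc(NS(=O)(=O)c3cc(C(=O)NO)ccc3Cl)ccc2n(C)c1=O` carries a free hydroxycarbamoyl group on a chloro-substituted benzene ring, and in this assay compound 1 gives 33%. Compound 2 `COc1ccc(C(=O)NOCc2ccccc2)cc1S(=O)(=O)Nc1ccc2c(c1)cc(C)c(=O)n2C` instead bears a methoxy-substituted ring whose carbamoyl oxygen is capped with a benzyl group, and in this assay compound 2 gives 13%. On the numbers shown, compound 2 stands as the lower of the two, with compound 1 higher by a margin that goes beyond the usual scatter.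

Compound 3 `COc1ccc(C(=O)NO)cc1S(=O)(=O)Nc1ccc2c(c1)cc(C)c(=O)n2C` is the uncapped counterpart of compound 2: hydrogen in place of benzyl on an oxygen. For the measured compounds named here, no step between two measured compounds covers this change directly, so the expectation rests on the observation that the only free hydroxycarbamoyl compound measured, compound 1, gives 33%. A moderate rise is therefore expected, with the step of a number 17 percentage points higher from compound 2 to compound 3 (beyond the scatter) in this assay. Compound 3 is estimated at 30%, with a range from 12% to 50%.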

Compound 3, a percentage reported as inhibition, at one concentration (the size of the read-out at that concentration, not a potency): 39%
Compound 3: middle estimate off by 9 percentage points, on the low side, and the stated range covers the measured number.
By their numbers in this assay, from the lowest: compound 2; then compounds 1 and 3 (each within the scatter of the next).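

In this assay, for the compounds shown here, hydrogen in place of benzyl on an oxygen gives a number 26 percentage points higher from compound 2 to compound 3 (beyond the scatter) with the rest of the molecule held constant, which isolates the change from (benzyloxy)carbamoyl to hydroxycarbamoyl in a single pair for the first time. Methoxy in place of chloro on an aromatic carbon gives a number 6 percentage points higher from compound 1 to compound 3 (within the scatter) among the compounds with a free hydroxycarbamoyl group, so in this pair the exchange of ring substituent cannot be told from the scatter, while the benzyl step lies beyond it. The data offer no independent measurement that would explain either result.

The compounds shown do not tell whether a smaller group on that oxygen, such as methyl or acetyl, would give a read-out closer to that of the benzyl compound or to that of the free hydroxycarbamoyl compounds. They also leave open whether the hydroxycarbamoyl group could be replaced by a carboxylic acid or a primary amide, and whether a fluoro or methyl group on the aromatic carbon would match methoxy and chloro.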